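Triazolyl purine nucleosides: chloro to methoxy on the benzyl

This account rests on a few compounds, and the source may have more. Where it says the series, first, only, none or still open, it means among the compounds named here.

Measured in an assay on CHO cells for displacement of a labelled ligand from adenosine receptor A3 (Homo sapiens); a higher number here means a weaker inhibitor, a lower number a stronger inhibitor:
compound 1 `CNc1nc(-n2cc(CC3CCCCC3)nn2)nc2c1ncn2[C@@H]1O[C@H](CO)[C@@H](O)[C@H]1O` gives 21.3 nM
compound 2 `CNc1nc(-c2cn(Cc3cccc(Cl)c3)nn2)nc2c1ncn2[C@@H]1O[C@H](CO)[C@@H](O)[C@H]1O` gives 81.1 nM
compound 3 `COc1ccc(Cl)c(CNc2nc(-n3cc(CC4CCCC4)nn3)nc3c2ncn3[C@@H]2O[C@H](CO)[C@@H](O)[C@H]2O)c1` gives 18 nM

Compound 2 gives the highest number of the three, and both of its gaps lie beyond the usual scatter: compound 1 and compound 3 sit at clearly lower numbers in this assay. Compound 2 is thus the weakest binder of the measured set. Among the compounds with values here, no pair of measured compounds differs in a single place, so no step can be used as a direct yardstick for the change considered here.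

Compound 4 `CNc1nc(-c2cn(Cc3cccc(OC)c3)nn2)nc2c1ncn2[C@@H]1O[C@H](CO)[C@@H](O)[C@H]1O` is the yet unmeasured partner of compound 2. The difference between them is methoxy in place of chloro on an aromatic carbon. The swap keeps the 3-chlorobenzyl to 3-methoxybenzyl framework intact and alters only the substituent on the benzyl ring.

Within the data shown here, with no measured step for this kind of exchange, the expectation is a step from compound 2 to compound 4 of modest size, a 1.4-fold higher number from compound 2 to compound 4 (0.13 log units; within the scatter), most likely towards a somewhat higher number, though a result within the scatter would not be surprising. On this basis compound 4 is estimated at 110 nM in this assay, with a plausible range from 35 nM to 350 nM.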

Compound 4, inhibition constant: 86.1 nM
For compound 4 the middle estimate is 1.3-fold (0.11 log units) above the measured one; measured number inside the range.
By their numbers in this assay, from the lowest: compounds 3 and 1 (each within the scatter of the next); then compounds 2 and 4 (each within the scatter of the next).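

Exchanging chloro for methoxy on the benzyl ring gives a 1.1-fold higher number from compound 2 to compound 4 (0.03 log units; within the scatter) in this assay and so does not separate the two groups at this position, on an aromatic carbon meta to a large group. Within the data shown here, the read-out stays within the scatter even though methoxy adds a heavy atom and a hydrogen-bond acceptor, and this is the only step that isolates a single change, so the finding applies to this pair and not beyond it. Nothing available on the compounds accounts for this match between chloro and methoxy at this position.

Open, on these data alone, is whether this tolerance extends to other groups on the same aromatic carbon, such as an amine, a hydroxyl, a carboxylic acid or a longer chain like butoxy, or whether the ring needs a substituent here at all, which the plain benzyl group would test. Also open, as far as these compounds go, is whether the same exchange gives a similarly small step when the benzyl ring sits on a different framework, such as those of compound 1 and compound 3.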